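Trimethoxyphenyl in place of amidoxime-bearing phenyl on the biaryl

The source may report more compounds than this note shows. Statements on the series, on what has been measured and on what is new or still open speak of the compounds shown alone.

This series shares one core and varies the group on the phenyl ring that sits on the quaternary carbon of the core. Compound 1 `CC1(c2ccc(-c3ccco3)cc2)CC(S(=O)(=O)c2ccc(F)cc2)=C(c2ccc(/C(N)=N\O)cc2)O1` carries a furan-2-yl there and in an ADME assay on HepG2 cells (Homo sapiens) for cytotoxicity, read by MTT assay, with a stated time of 72 h (on this read-out lower numbers stand for higher toxicity in this test and higher numbers for lower toxicity in this test), compound 1 gives 7010 nM. Compound 2 `CC1(c2ccccc2)CC(S(=O)(=O)c2ccc(F)cc2)=C(c2ccc(/C(N)=N\O)cc2)O1` carries hydrogen at that place, and compound 2 gives 68300 nM. Compound 3 `CC1(c2ccc(-c3cccc(/C(N)=N\O)c3)cc2)CC(S(=O)(=O)c2ccc(F)cc2)=C(c2ccc(/C(N)=N\O)cc2)O1` carries a second amidoxime-bearing phenyl, and compound 3 gives 19000 nM, the second highest of the three numbers: a 2.7-fold higher number from compound 1 to compound 3 (0.43 log units; beyond the scatter), while a 3.6-fold lower number from compound 2 to compound 3 (0.56 log units; beyond the scatter).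

Compound 4 `COc1cc(-c2ccc(C3(C)CC(S(=O)(=O)c4ccc(F)cc4)=C(c4ccc(/C(N)=N\O)cc4)O3)cc2)cc(OC)c1OC` differs from compound 3 by a group of 12 heavy atoms (9 carbon, 3 oxygen; one six-membered aromatic ring of carbon only) in place of a group of 10 heavy atoms (7 carbon, 2 nitrogen, 1 oxygen; one six-membered aromatic ring of carbon only), on an aromatic carbon. Going by the values given here, no measured step involves a trimethoxyphenyl, so the closest guidance is indirect. The two steps that attach an aromatic group to this carbon, a 3.6-fold lower number from compound 2 to compound 3 (0.56 log units; beyond the scatter) and a 9.7-fold higher number from compound 1 to compound 2 (0.99 log units; beyond the scatter), both show that an aromatic substituent at this place gives a lower number than hydrogen, and the exchange of one aromatic group for another in a 2.7-fold higher number from compound 1 to compound 3 (0.43 log units; beyond the scatter) stayed modest. Compound 4 is therefore expected to stay in the range of compound 1 and compound 3, with a step of a 1.6-fold lower number from compound 3 to compound 4 (0.20 log units; within the scatter) in this assay. The estimate for compound 4 is 12000 nM, within 4000 nM to 36000 nM.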

Compound 4, half-maximal cytotoxic concentration: > 50000 nM
Compound 4: a limit, no number; the forecaster's own chance of this, stated with the estimate: 5%; middle value at least 4.1-fold (0.61 log units) away from the limit.
By their numbers in this assay, from the lowest: compound 1; then compound 3; then compound 2.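

In this assay, compound 4 gives a limit and not a number: the limit of > 50000 nM in this assay, at which 1 of the 4 values shown sits.

Even so, the exchange at this position can be read against two neighbours: 3,4,5-trimethoxyphenyl gives an at least 2.6-fold higher number from compound 3 to compound 4 (0.42 log units; beyond the scatter) and an at least 7.1-fold higher number from compound 1 to compound 4 (0.85 log units; beyond the scatter), so the identity of the aromatic group matters more here than compounds 1 and 3 alone showed, and an aromatic group at this carbon does not in itself bring the number down to their range. The step from compound 2 to compound 4 cannot be read, so whether 3,4,5-trimethoxyphenyl gives a number above or below that of hydrogen stays undecided.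

The compounds shown leave open how far the number of compound 4 lies beyond its limit, and whether the change follows from the methoxy groups as a set or from the one group alone. A phenyl carrying a single methoxy group, or a phenyl carrying an amine or a carboxylic acid, at this place on the shared core would show whether the higher number belongs to 3,4,5-trimethoxyphenyl only.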